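The compounds below may be only part of what the source reports. "The series", "measured", "known", "first", "only" and "open" are said of these compounds alone.

Compound 1 `CC(=O)Nc1ccc(CN2CCC=C(CCC(=O)NO)C2=O)cc1` - "not determined" (no result reported)
Compound 2 `COc1ccc(CN2CCC=C(CCC(=O)NO)C2=O)cc1` - 3860 nM
Compound 3 `Cc1ccccc1CN1CCC=C(CCC(=O)NO)C1=O` - 4920 nM

In a functional assay on MDA-MB-231 cells (Homo sapiens) for inhibition, read by sulforhodamine B assay (on this read-out lower numbers stand for stronger inhibition of growth and higher numbers for weaker inhibition of growth), compound 3 gives 4920 nM, within the scatter of compound 2 at 3860 nM, while compound 1 offers no number for comparison. Compound 4 `O=C(CCC1=CCCN(Cc2ccc(Br)cc2)C1=O)NO` carries 4-bromophenyl in place of 2-methylphenyl on a saturated chain carbon bound to an amide-type nitrogen in a ring. Among the measured compounds shown here, no measured step isolates this change. Compound 2 (3860 nM) and compound 3 (4920 nM) lie within the scatter of each other, so no step beyond the scatter is expected in this assay. The expected step (a 1.3-fold lower number from compound 3 to compound 4 (0.11 log units; within the scatter)) therefore stays small. For compound 4 the estimated value is 3800 nM, with an expected range of 1700 nM to 8500 nM.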

Compound 4, concentration for 50% growth inhibition: 1630 nM
The estimate for compound 4 lay 2.3-fold (0.37 log units) above the measured number, outside the stated range (below it).
By their numbers in this assay, from the lowest: compound 4; then compounds 2 and 3 (each within the scatter of the next).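

In this assay the aryl group on a saturated chain carbon bound to an amide-type nitrogen in a ring now shows a step beyond the scatter, with a 3.0-fold lower number from compound 3 to compound 4 (0.48 log units; beyond the scatter) for 4-bromophenyl in place of 2-methylphenyl and a 2.4-fold lower number from compound 2 to compound 4 (0.37 log units; beyond the scatter) for bromo in place of methoxy on an aromatic carbon. Among the compounds shown here, compound 2 and compound 3 alone showed no such step. No measured evidence bears on the reason for either step.

From the compounds shown here alone, whether the step from compound 3 follows the bromo itself or its place on the aromatic ring stays open. Also open, going by these compounds, is whether chloro or a carboxylic acid on the same aromatic carbon would read like bromo.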